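Sulfonylhydrazide to hydroxy on the amide nitrogen: outlook for compound 3

This account rests on a few compounds, and the source may have more. Where it says the series, first, only, none or still open, it means among the compounds named here.

Measured compounds:
compound 1 `CCCCS(=O)(=O)NNC(=O)[C@@H](NC(=O)c1cccc(Cn2ccnc2)c1)[C@@H](C)CC` — "not determined" (no result reported)
compound 2 `CC[C@H](C)[C@H](NC(=O)c1cccc(Cn2ccnc2)c1)C(=O)NNS(=O)(=O)c1ccc(C)cc1` — 20%

In an assay on HEK293 cells for displacement of a labelled ligand from Type-2 angiotensin II receptor (Homo sapiens), tested at 10 uM (on this read-out lower numbers stand for a weaker effect and higher numbers for a stronger effect at the one concentration tested), compound 2 gives 20%. For compound 1 the same read-out is recorded as "not determined" (no result reported), so compound 1 stands on no number in this assay, and its place relative to compound 2 cannot be fixed from the data. Among the measured compounds shown here, compound 1 and compound 2 share the core and differ in the group on the sulfonyl; no step between them is tabulated, and only the value of compound 2 is available as an anchor for the series.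

The unmeasured compound 3 `CC[C@H](C)[C@H](NC(=O)c1cccc(Cn2ccnc2)c1)C(=O)NO` differs from compound 1 in one place:
hydroxy in place of (butylsulfonyl)amino on an amide-type nitrogen

For the measured compounds named here, no pair of measured compounds differs in a single place, so no step of this kind has been observed and the size of the change in this assay cannot be read off. With only the low read-out of compound 2 as reference, a step beyond the scatter in either direction is not expected for compound 3; the more likely outcome is a read-out of the same order, a weak effect at the concentration tested.

Compound 3 is estimated to give 15% in this assay. The expected range for compound 3 runs from 0% to 40%.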

Compound 3, a percentage reported as inhibition, at one concentration (the size of the read-out at that concentration, not a potency): 4%
Compound 3: middle estimate off by 11 percentage points, on the high side, and the stated range covers the measured number.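

In this assay, among the compounds shown here, hydroxy in place of ((4-methylphenyl)sulfonyl)amino on an amide-type nitrogen gives a number 16 percentage points lower from compound 2 to compound 3 (beyond the scatter), the first readable step at this position, and it shows that the read-out depends on the group there, although it stays low at the one concentration tested. Compound 1 carries "not determined" (no result reported), so the step from compound 1 to compound 3 cannot be read, and the (butylsulfonyl)amino group cannot be ranked against either hydroxy or ((4-methylphenyl)sulfonyl)amino. Nothing available accounts for the lower read-out of compound 3.

The compounds shown leave open whether the higher read-out of compound 2 belongs to the 4-methylphenyl group specifically or is shared by other sulfonyl groups, such as an unsubstituted phenylsulfonyl or a longer alkyl chain on the sulfonyl. They also leave open how a methoxy group or a plain amine on the same amide-type nitrogen would compare with hydroxy, and whether any group there can clearly improve on the read-out in this assay of compound 2, which gives 20%.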